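Working notes: from compound 3 to compound 4

This account rests on a few compounds, and the source may have more. Where it says the series, first, only, none or still open, it means among the compounds named here.

- compound 1 (`C#Cc1cccc(Nc2ncnc3cc(OC)c(OCCCN4CCNCCNCC4)cc23)c1`) > 50000 nM
- compound 2 (`COc1cc2ncnc(Nc3cccc(Br)c3)c2cc1OCCCN1CCNCCNCC1`) 34300 nM
- compound 3 (`COc1cc2ncnc(Nc3cccc(Cl)c3)c2cc1OCCCN1CCNCCNCC1`) > 50000 nM

Within the data shown here, in a functional assay on A549 cells (Homo sapiens) for antiproliferative activity, read by MTT assay, with a stated time of 72 h (on this read-out higher numbers stand for weaker inhibition and lower numbers for stronger inhibition), compound 2 gives 34300 nM as the only true number of the set. Compound 1 reaches only a limit (> 50000 nM). Compound 3 likewise stands only at a limit (> 50000 nM), so its place is bounded and not fixed.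

Compound 4 (`COc1cc2ncnc(Nc3ccc(C#N)cc3F)c2cc1OCCCN1CCNCCNCC1`) carries 4-cyano-2-fluorophenyl in place of 3-chlorophenyl on a nitrogen on an aromatic ring.

Three measured swaps on that ring bear on this: (an at least 1.4-fold lower number from compound 1 to compound 2 (0.16 log units; that floor lies within the scatter)), (an at least 1.4-fold higher number from compound 2 to compound 3 (0.16 log units; that floor lies within the scatter)) and (a step that the two limits leave unreadable from compound 1 to compound 3). All are bounded by the limit of > 50000 nM in this assay, at which 2 of the 3 values shown sit, and none is shown beyond the scatter. No step beyond the scatter is therefore expected in this assay and no direction can be told. The expected step reads (an at least 1.2-fold lower number from compound 3 to compound 4 (0.09 log units; that floor lies within the scatter)), and another limit would be no surprise. Compound 4 is estimated at 40000 nM (expected range: 18000 nM to 80000 nM).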

Compound 4, half-maximal inhibitory concentration: > 50000 nM
Compound 4 ended at the assay's limit; the forecaster's own chance of this, stated with the estimate: 50%; at least 1.2-fold (0.09 log units) between middle value and limit.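

In this assay compound 4 gives > 50000 nM, and this is a limit of the assay, not a number. Among these compounds, the only readable step is an at least 1.4-fold higher number from compound 2 to compound 4 (0.16 log units; that floor lies within the scatter), while the steps from compound 1 and from compound 3 to compound 4 cannot be read. Exchanging the whole aryl group on the nitrogen, rather than one substituent on it, still gives no second true value beside compound 2, so this position remains poorly resolved: the limit of > 50000 nM in this assay, at which 3 of the 4 values shown sit.

On these data alone, whether any group on this nitrogen can bring the series clear of the limit stays open. As far as these compounds go, all four compounds share the same core and side chain, so what a morpholine at the end of a shorter chain would give also stays open.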